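Benzyl in place of methoxyphenyl on the amine nitrogen

A few compounds are considered here, and "the series" means these few. Any claim that something is new, unique, unknown or untested is made for them only; others in the source may bear on it.

In a functional assay on ECa-109 cells for inhibition, with ECa-109 cell line (Homo sapiens) as the target, read by sulforhodamine B assay (a lower number here means a stronger inhibitor, a higher number a weaker inhibitor), compound 1, `COc1ccccc1NC1=CC(=O)c2c(nc3n2[C@H]2OC[C@@H](O)[C@H]2OC3)C1=O`, reaches only a limit, > 4000 nM. Compound 2, `O=C1C=C(Nc2ccccc2)C(=O)c2c1nc1n2[C@H]2OC[C@@H](O)[C@H]2OC1`, gives a number in this assay, 4970 nM. Compound 3, `CCCc1ccc(NC2=CC(=O)c3nc4n(c3C2=O)[C@H]2OC[C@@H](O)[C@H]2OC4)cc1`, again ends at a limit, > 4000 nM. For the measured compounds named here, the single step that can be drawn between measured compounds, a step that the limit leaves unreadable from compound 2 to compound 3, is therefore not readable, and compound 1 sits at the limit of > 4000 nM in this assay, at which 2 of the 3 values shown sit, so no order among the three can be stated; all that is known is that none of them reads as a strong inhibitor.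

The change to compound 4, `O=C1C(NCc2ccccc2)=CC(=O)c2c1nc1n2[C@H]2OC[C@@H](O)[C@H]2OC1`: benzyl in place of 2-methoxyphenyl on an amine nitrogen. Going by the values given here, no measured pair shows this kind of change, and the one measured step runs into the limit, so no size can be carried over from it. Among the compounds with values here, what the three measured compounds show is that each variation so far has left this assay at or just past its limit. The expectation for compound 4 is a step that the limit leaves unreadable from compound 1 to compound 4, which is to say no movement that could be told from the scatter, with a further limit the most likely outcome. Compound 4 is estimated at 6000 nM, within a range from 2500 nM to 15000 nM.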

Compound 4, half-maximal inhibitory concentration: > 8000 nM
Compound 4 ended at the assay's limit; the forecaster's own chance of this, stated with the estimate: 60%; middle value at least 1.3-fold (0.12 log units) from the limit.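

Compound 1 reads only as a limit, > 4000 nM. For the compounds shown here, compound 4 also reads only as a limit, > 8000 nM, so no step between compound 1 and compound 4 can be read. Still open, going by these compounds, is whether benzyl in place of 2-methoxyphenyl on the amine nitrogen changes inhibition of these cells at all.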